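Removing the methylsulfonyl piperazine of compound 3

The source may report more compounds than this note shows. Statements on the series, on what has been measured and on what is new or still open speak of the compounds shown alone.

Measured in a physicochemical assay for solubility, read by nephelometry, measured as kinetic solubility, with a stated time of 30 min; a lower number here means a less soluble compound, a higher number a more soluble compound:
- Compound 1 `NCCOc1ccc([C@H]2CC[C@]3(CC2)OOC2(O3)C3CC4CC(C3)CC2C4)cc1`: > 100 ug/mL, a limit
- Compound 2 `CC(C)(N)CCOc1ccc([C@H]2CC[C@]3(CC2)OOC2(O3)C3CC4CC(C3)CC2C4)cc1`: 50 ug/mL
- Compound 3 `CS(=O)(=O)N1CCN(CCCOc2ccc([C@H]3CC[C@]4(CC3)OOC3(O4)C4CC5CC(C4)CC3C5)cc2)CC1`: < 1.6 ug/mL, a limit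

Compound 3, held only by its limit of < 1.6 ug/mL, sits lowest of the three. Compound 4 `c1cc([C@H]2CC[C@]3(CC2)OOC2(O3)C3CC4CC(C3)CC2C4)ccc1OCC1CCNCC1` arises from compound 3 by one change: piperidin-4-yl in place of 2-(4-(methylsulfonyl)piperazin-1-yl)ethyl on a saturated chain carbon bound to an oxygen on an aromatic ring. Within the data shown here, two measured steps bear on this change: an at least 62-fold lower number from compound 1 to compound 3 (1.79 log units; beyond the scatter) and an at least 31-fold lower number from compound 2 to compound 3 (1.49 log units; beyond the scatter). Both are large, and both end at the methylsulfonyl piperazine that compound 4 gives up. Read in reverse, they lead to the expectation of a large rise in this assay. The expected step is an at least 31-fold higher number from compound 3 to compound 4 (1.49 log units; beyond the scatter). For compound 4 the estimated value is 50 ug/mL, with an expected range from 12 ug/mL to 100 ug/mL.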

Compound 4, solubility: 12.5 ug/mL
For compound 4 the middle estimate is 4.0-fold (0.60 log units) above the measured one, and the stated range covers the measured number.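

In this assay, the change gives an at least 7.8-fold higher number from compound 3 to compound 4 (0.89 log units; beyond the scatter), so a six-membered non-aromatic ring at this place does not by itself hold the number at a limit. Still, piperidin-4-yl does not match the open-chain amines, with a 4.0-fold lower number from compound 2 to compound 4 (0.60 log units; beyond the scatter) and an at least 8.0-fold lower number from compound 1 to compound 4 (0.90 log units; beyond the scatter). The steps involving compound 1 and compound 3 rest on limits, and their full size cannot be read.

Going by these compounds, what stays open is whether the rise follows the loss of the methylsulfonyl group or the shorter chain. A plain piperazine on the same chain as compound 3, or piperidin-4-yl on a longer chain, would separate the two.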